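Swapping the amine on compound 3

The source may report more compounds than this note shows. Statements on the series, on what has been measured and on what is new or still open speak of the compounds shown alone.

Compound 1 `Oc1c(CN2CCCC2)cc(Cl)c2cccnc12`: 3460 nM; 3390 nM (2 entries)
Compound 2 `COCc1cc(CN2CCCC2)c(O)c2ncccc12`: 11000 nM
Compound 3 `CCOCc1cc(CN2CCCC2)c(O)c2ncccc12`: 8510 nM

All three compounds were tested in a functional assay on MES-SA cells (Homo sapiens) for inhibition, with a stated time of 72 h; on this read-out lower numbers stand for stronger inhibition and higher numbers for weaker inhibition. There compound 3 gives 8510 nM, which lies within the scatter of compound 2 at 11000 nM. Compound 1 shows a lower number, and its readings agree closely: the several entries of compound 1 in this assay, 3460 nM; 3390 nM (2 entries).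

The next compound is compound 4 `CCOCc1cc(CN2CCC(C)CC2)c(O)c2ncccc12`. It carries 4-methylpiperidin-1-yl in place of pyrrolidin-1-yl on a saturated chain carbon bound to an aromatic carbon.

Only one measured step links two of these compounds: a 1.3-fold lower number from compound 2 to compound 3 (0.11 log units; within the scatter). That step is small, but it changes a different part of the molecule. All three measured compounds keep pyrrolidin-1-yl, so no measurement shows what replacing that group does in this assay. Among the measured compounds shown here, with no measured step pointing either way, no shift beyond the scatter is expected, and the estimate stays close to compound 3 at 8510 nM, with a wide range. The expected change is a 1.3-fold lower number from compound 3 to compound 4 (0.12 log units; within the scatter). For compound 4 the estimated value is 6500 nM, with an expected range from 2200 nM to 16000 nM.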

Compound 4, half-maximal inhibitory concentration: 4070 nM
Beside the measured number, compound 4's estimate is 1.6-fold (0.20 log units) above it; the measured number falls inside the stated range.
By their numbers in this assay, from the lowest: compound 4; then compounds 3 and 2 (each within the scatter of the next).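

Among the compounds shown here, of the changes measured on this core, the swap of pyrrolidin-1-yl for 4-methylpiperidin-1-yl on the saturated chain carbon bound to an aromatic carbon is the first to move the number in this assay beyond the scatter: it gives a 2.1-fold lower number from compound 3 to compound 4 (0.32 log units; beyond the scatter). The earlier change on the ether chain, a 1.3-fold lower number from compound 2 to compound 3 (0.11 log units; within the scatter), stayed within the scatter, so this amine position responds to substitution in a way the first step did not reveal, although the effect is modest. For the compounds shown here, compounds 3 and 4 each rest on a single reading, while the one compound with repeat readings gave numbers that agree closely: the several entries of compound 1 in this assay, 3460 nM; 3390 nM (2 entries).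

The swap changes a five-membered ring to a six-membered ring and brings in a methyl group at the same time, so the compounds shown leave open which of these accounts for the step, a question that unsubstituted piperidin-1-yl on the same core would help to settle. Also open, on these data alone, is whether morpholin-4-yl or an open-chain amine such as diethylamino would keep the lower number seen with compound 4.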